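A few compounds are considered here, and "the series" means these few. Any claim that something is new, unique, unknown or untested is made for them only; others in the source may bear on it.

In a functional assay on CCRF-CEM cells (Homo sapiens) for antiproliferative activity, with a stated time of 72 h (on this read-out higher numbers stand for weaker inhibition and lower numbers for stronger inhibition), compound 1 `OC[C@H]1O[C@@H](n2cnc3c(NCc4cccc(F)c4)ncnc32)[C@H](O)[C@@H]1O` gives 4000 nM, compound 2 `COc1ccccc1CNc1ncnc2c1ncn2[C@@H]1O[C@H](CO)[C@@H](O)[C@H]1O` gives 3200 nM and compound 3 `OC[C@H]1O[C@@H](n2cnc3c(NCc4ccc(F)cc4F)ncnc32)[C@H](O)[C@@H]1O` gives 7100 nM. All three share one core and differ only in the substituted phenyl on a saturated chain carbon bound to a nitrogen on an aromatic ring. Compound 3 shares the upper end of this small set with compound 1, and only compound 2 stands clearly apart. The two steps that show this are a 1.8-fold higher number from compound 1 to compound 3 (0.25 log units; within the scatter) and a 2.2-fold higher number from compound 2 to compound 3 (0.35 log units; beyond the scatter).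

Compound 4 `OC[C@H]1O[C@@H](n2cnc3c(NCc4c(F)ccc(F)c4F)ncnc32)[C@H](O)[C@@H]1O` has 2,3,6-trifluorophenyl in place of the 2,4-difluorophenyl of compound 3 (2,3,6-trifluorophenyl in place of 2,4-difluorophenyl on a saturated chain carbon bound to a nitrogen on an aromatic ring). Among the measured compounds shown here, no measured compound carries this group, so the closest guide is the other swaps at the same place. Besides the two steps above, these include a 1.3-fold lower number from compound 1 to compound 2 (0.10 log units; within the scatter), so all of them are small. In this assay a step no larger than the scatter is therefore expected, with no firm direction. The expected step is a 1.4-fold lower number from compound 3 to compound 4 (0.15 log units; within the scatter). Compound 4 is estimated at 5000 nM, with an expected range from 2000 nM to 12000 nM.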

Compound 4, half-maximal inhibitory concentration: 90300 nM
The estimate for compound 4 lay 18-fold (1.26 log units) below the measured number, outside the stated range (above it).
By their numbers in this assay, from the lowest: compounds 2, 1 and 3 (each within the scatter of the next, the first and the last beyond it); then compound 4.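

Until now the swaps at this place, on a saturated chain carbon bound to a nitrogen on an aromatic ring, had moved the number in this assay only a little, but 2,3,6-trifluorophenyl brings a 13-fold higher number from compound 3 to compound 4 (1.10 log units; beyond the scatter) with the same large loss seen as a 28-fold higher number from compound 2 to compound 4 (1.45 log units; beyond the scatter) and as a 23-fold higher number from compound 1 to compound 4 (1.35 log units; beyond the scatter) against the other two compounds. This place is therefore not indifferent to the substituted phenyl it carries, and compound 4 is the weakest of the four. No data at hand explain why this group is so much worse than the others.

On these data alone, compound 4 alone carries three fluorines, so it stays open whether the loss follows their number or their arrangement on the ring. As far as these compounds go, how chlorine or a methyl group on the phenyl would fare also remains unknown.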